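The compounds below may be only part of what the source reports. "The series", "measured", "known", "first", "only" and "open" are said of these compounds alone.

Working notes on the series. Compound 1 `CC(=O)N1c2ccccc2CCC1C(=O)Nc1ccccc1O` gives 50700 nM in a functional assay on ACHN cells (Homo sapiens) for cytotoxicity, read by sulforhodamine B assay, with a stated time of 72 h; a lower number here means a stronger inhibitor of growth, a higher number a weaker inhibitor of growth. Compound 2 `O=C(Nc1ccc(C(F)(F)F)cc1)C1CCc2ccccc2N1` gives 25000 nM in this assay. Compound 3 `CCCCCCCCC(=O)N1c2ccccc2CCC1C(=O)Nc1ccccc1C(F)(F)F` gives the lowest of the three numbers, 8330 nM in this assay, with compound 2 nearest and compound 1 furthest, both gaps beyond the scatter. Compound 4 `O=C(Nc1ccccc1C(F)(F)F)C1CCc2ccccc2N1C(=O)c1cccc(Cl)c1` is not yet measured. The change from compound 3 is 3-chlorophenyl in place of octyl on a carbonyl carbon. Within the data shown here, no measured pair shows this exchange, so the size of the step cannot be read from the data. The expectation for compound 4 is a step of a 1.2-fold higher number from compound 3 to compound 4 (0.08 log units; within the scatter) in this assay, that is, no change beyond the scatter in either direction. Compound 4 is therefore estimated at 10000 nM in this assay, within the range 3000 nM to 33000 nM.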

Compound 4, concentration for 50% growth inhibition: 526 nM
For compound 4 the middle estimate is 19-fold (1.28 log units) above the measured one, and the stated range ends above it.
By their numbers in this assay, from the lowest: compound 4; then compound 3; then compound 2; then compound 1.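

On a carbonyl carbon whose other neighbour is the amide-type nitrogen in a ring, 3-chlorophenyl in place of octyl gives a 16-fold lower number from compound 3 to compound 4 (1.20 log units; beyond the scatter) in this assay. This first one-place comparison in the series shows that the group at this position can move the number well beyond the scatter, and that octyl is not required for a low number. Still open, as far as these compounds go, is whether the aromatic ring or its chlorine accounts for the step, which a plain phenyl or a 3-methoxyphenyl would test. No measurement here explains the size of the step.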